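The compounds below may be only part of what the source reports. "The series", "measured", "known", "first", "only" and "open" are said of these compounds alone.

Measured so far:
compound 1 `COc1cc(-c2nn(-c3cccc(NC(=O)Nc4cc(C(F)(F)F)cc(C(F)(F)F)c4)c3)cc2-c2ccncc2)ccc1Cl`: 1610 nM
compound 2 `COc1cc(-c2nn(-c3cccc(NC(=O)c4cccc(C(F)(F)F)c4)c3)cc2-c2ccncc2)ccc1Cl`: 20100 nM

In a functional assay on HT-29 cells (Homo sapiens) for inhibition, read by sulforhodamine B assay, with a stated time of 48 h (on this read-out higher numbers stand for weaker inhibition of growth and lower numbers for stronger inhibition of growth), compound 2 has the higher of the two numbers shown, and compound 1 gives the lower one, a gap well beyond the usual scatter. Compound 3 `COc1cc(-c2nn(-c3cccc(NC(=O)Nc4ccc(Cl)c(Cl)c4)c3)cc2-c2ccncc2)ccc1Cl` is compound 2 with (3,4-dichlorophenyl)amino in place of 3-(trifluoromethyl)phenyl on a carbonyl carbon. A hydrogen-bond donor thereby enters on the carbonyl carbon, as compound 1 also carries one. Because compound 1 gives 1610 nM while compound 2 gives 20100 nM, the step of an 8.0-fold lower number from compound 2 to compound 3 (0.91 log units; beyond the scatter) is expected to be a clear drop beyond the scatter. Compound 3 is therefore estimated at 2500 nM, within 800 nM to 8000 nM.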

Compound 3, concentration for total growth inhibition: 6460 nM
Compound 3: middle estimate off by 2.6-fold (0.41 log units), on the low side, and the stated range covers the measured number.
By their numbers in this assay, from the lowest: compound 1; then compound 3; then compound 2.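

In this assay, putting (3,4-dichlorophenyl)amino in place of 3-(trifluoromethyl)phenyl on a carbonyl carbon gives a 3.1-fold lower number from compound 2 to compound 3 (0.49 log units; beyond the scatter), so growth inhibition responds to a change at this position. The change alters the ring's substituents and adds a hydrogen-bond donor together, so these compounds cannot show which part matters. No measurement shown explains the step. As far as these compounds go, a (3-(trifluoromethyl)phenyl)amino group on this carbonyl carbon would add the donor while keeping the substituent of compound 2, and its effect remains open. From the compounds shown here alone, whether a simple methylamino group would be enough also remains open.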